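Working notes: compound 2 to compound 4 in one series

The source may report more compounds than this note shows. Statements on the series, on what has been measured and on what is new or still open speak of the compounds shown alone.

In an assay on HEK293 cells for inhibition of sodium channel protein type 3 subunit alpha (Homo sapiens), read by electrophysiology, with a stated time of 3.5 min (a higher number here means a weaker inhibitor, a lower number a stronger inhibitor), compound 1 `CN1[C@@H](c2ccc(OCc3ccccc3F)cc2)CC[C@H]1C(N)=O` gives > 100000 nM, which is a limit of the assay and not a number. Compound 3 `NC(=O)[C@@H]1CC[C@H](c2ccc(OCc3ccc(F)cc3)cc2)N1` gives > 63000 nM in this assay, again a limit and not a number. Among the measured compounds shown here, compound 2 `O=C1NCCC1NCc1ccc(OCc2ccccc2F)cc1` is therefore the only member with a measured number in this assay, where compound 2 gives 126000 nM. Compound 4 `NC(=O)CNCc1ccc(OCc2ccccc2F)cc1` is not yet measured. It differs from compound 2 in one place: carbamoylmethyl in place of 2-oxopyrrolidin-3-yl on an amine nitrogen. For the measured compounds named here, no step between measured compounds is available for this change, so the size cannot be taken from the series. The expectation is that the step from compound 2 to compound 4 in this assay stays within the usual scatter, a 1.2-fold higher number from compound 2 to compound 4 (0.08 log units; within the scatter), with no clear direction. On that basis compound 4 is estimated at 150000 nM in this assay, expected to fall between 50000 nM and 450000 nM.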

Compound 4, half-maximal inhibitory concentration: 50100 nM
Beside the measured number, compound 4's estimate is 3.0-fold (0.48 log units) above it; the measured number falls inside the stated range.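

In this assay the series now has its first readable step, a 2.5-fold lower number from compound 2 to compound 4 (0.40 log units; beyond the scatter), which shows that the group on this amine nitrogen can move the number by more than the usual scatter. The open-chain carbamoylmethyl has no ring and fewer heavy atoms than 2-oxopyrrolidin-3-yl, with the same counts of hydrogen-bond donors and acceptors, so the ring is not required for the modest inhibition seen in compound 2. Nothing shown accounts for the size or direction of this step.

A single step cannot separate the loss of the ring from the shorter group that replaces it. A longer chain such as carbamoylethyl, or a carboxylic acid in place of the primary amide on the same amine nitrogen, would show how far this trend extends.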